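Swapping the amide side chain in a vitamin D receptor agonist

The source may report more compounds than this note shows. Statements on the series, on what has been measured and on what is new or still open speak of the compounds shown alone.

Compound 1 `CCCCC(=O)c1ccc(C(CC)(CC)c2ccc(C#CC(O)(CC)CC)c(C)c2)n1CC` reaches only the assay limit of > 50 nM in an assay on cells for agonist activity at vitamin D3 receptor (Homo sapiens), read by microscopy (a lower number here means that less compound is needed, a higher number that more compound is needed for the effect), a limit rather than a number. Within the data shown here, compound 2 `CCN(CC)CCNC(=O)c1cc(C(CC)(CC)c2ccc(C#CC(O)(CC)CC)c(C)c2)cn1CC` gives 6.98 nM in this assay, the only number here, since the other value sits at the limit of > 50 nM in this assay, at which 1 of the 2 values shown sits. Compound 3 `CCn1cc(C(CC)(CC)c2ccc(C#CC(O)(CC)CC)c(C)c2)cc1C(=O)N[C@@H](C)CO` carries a different group on the amide nitrogen: 1-(hydroxymethyl)ethyl in place of 2-(diethylamino)ethyl on an amide-type nitrogen. Among the measured compounds shown here, no measured pair shows what such a change does here, so the expected step from compound 2 to compound 3 of a 2.1-fold higher number from compound 2 to compound 3 (0.33 log units; beyond the scatter) in this assay is a guess at a modest loss. Compound 3 is therefore estimated at 15 nM, within 4 nM to 60 nM.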

Compound 3, half-maximal effective concentration: 7.33 nM
The estimate for compound 3 lay 2.0-fold (0.31 log units) above the measured number; measured number inside the range.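

In this assay putting 1-(hydroxymethyl)ethyl in place of 2-(diethylamino)ethyl on the amide-type nitrogen gives a 1.1-fold higher number from compound 2 to compound 3 (0.02 log units; within the scatter) and so leaves the two compounds indistinguishable. This amide nitrogen can therefore carry either of these two quite different side chains, and the diethylamino group is not needed for this reading. Nothing measured here explains why the two side chains read alike.

As far as these compounds go, whether a carboxylic acid or a longer chain on this nitrogen would read the same remains open. So does what the defined stereocentre of compound 3 contributes.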